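The compounds below may be only part of what the source reports. "The series", "measured", "known", "first", "only" and "open" are said of these compounds alone.

Measured so far:
compound 1 `CC(C)(C)[Si](OCCCc1ccc(=O)[nH]n1)(c1ccccc1)c1ccccc1`, 78300 nM
compound 2 `O=c1ccc(CCCO)n[nH]1`, > 100000 nM (a limit)
compound 3 `Cn1nc(CCCO)ccc1=O`, > 100000 nM (a limit)

In a functional assay on aorta (Rattus norvegicus) (a lower number here means a stronger inhibitor, a higher number a weaker inhibitor), compound 1 gives 78300 nM. For compound 2 this assay reports only a limit, > 100000 nM. For compound 3 it likewise reports only a limit, > 100000 nM. Between compound 2 and compound 3 the step is a step that the two limits leave unreadable from compound 2 to compound 3; its size is hidden because of the limit of > 100000 nM in this assay, at which 2 of the 3 values shown sit. The difference between the core of compound 1 and that of compound 2 is not broken down here.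

Compound 4 `Cn1nc(CCCO[Si](c2ccccc2)(c2ccccc2)C(C)(C)C)ccc1=O` has not been measured. It differs from compound 1 by methyl in place of hydrogen on an aromatic nitrogen, the same kind of change as methyl in place of hydrogen on an aromatic nitrogen, the surroundings differing only in that the place is meta to a large group in one case and meta to a 3-hydroxypropyl group (4 heavy atoms) in the other. Since the measured step from compound 2 to compound 3 is unreadable, the expectation for compound 4 rests mainly on compound 1 at 78300 nM, and a step of a 1.2-fold higher number from compound 1 to compound 4 (0.08 log units; within the scatter) is estimated. Compound 4 is thus expected to give about 95000 nM in this assay, within 30000 nM to 250000 nM.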

Compound 4, half-maximal inhibitory concentration: > 100000 nM
Compound 4: a limit, no number; the forecaster's own chance of this, stated with the estimate: 45%; middle value at least 1.0-fold (0.02 log units) away from the limit.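

In this assay, methyl in place of hydrogen on an aromatic nitrogen gives an at least 1.2-fold higher number from compound 1 to compound 4 (0.10 log units; that floor lies within the scatter), so on the core of compound 1 the change yields only a floor, and that floor lies within the usual scatter. The same change on the core of compound 2 cannot be read, and the two steps cannot be compared, because both values of that pair are limits: the limit of > 100000 nM in this assay, at which 3 of the 4 values shown sit. The compounds therefore do not show whether the change carries from one core to the other with the same size, or how large it truly is on either.

The compounds shown leave open how far the number for compound 4 lies from that of compound 1. They also leave open what an amine or a carboxylic acid in place of the silyl ether of compound 1 would give in this assay.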